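The source may report more compounds than this note shows. Statements on the series, on what has been measured and on what is new or still open speak of the compounds shown alone.

Working notes on the sulfonamide series in a functional assay on HT-29 cells (Homo sapiens) for inhibition, read by MTT assay, with a stated time of 72 h; a higher number here means a weaker inhibitor of growth, a lower number a stronger inhibitor of growth. Two compounds have numbers. Compound 1 `O=S(=O)(NCCCNCc1ccc(Cl)cc1)c1cc(C(F)(F)F)cc(C(F)(F)F)c1` gives 2800 nM. Compound 2 `CC(C)(C)c1ccc(CNCCCNS(=O)(=O)c2cc(C(F)(F)F)cc(C(F)(F)F)c2)cc1` gives 2000 nM. For the measured compounds named here, the only step so far, a 1.4-fold lower number from compound 1 to compound 2 (0.15 log units; within the scatter), does not separate the two, so compound 2 stands at a number indistinguishable from that of compound 1 rather than apart from it.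

Compound 3 `O=S(=O)(NCCCNCc1ccc(Cl)c(C(F)(F)F)c1)c1cc(C(F)(F)F)cc(C(F)(F)F)c1` is the next member. Its difference from compound 2 is 4-chloro-3-(trifluoromethyl)phenyl in place of 4-(tert-butyl)phenyl on a saturated chain carbon bound to an amine nitrogen. Going by the values given here, the one measured step bears on it only in part: it exchanged chloro for tert-butyl on the aromatic carbon of this same ring and stayed within the scatter, and compound 3 carries the chloro of compound 1 again. Among the compounds with values here, the added trifluoromethyl on that ring has no measured counterpart, so nothing here points to a step beyond the scatter in either direction. The expectation for compound 3 is therefore a number close to that of compound 2, with the step of a 1.3-fold higher number from compound 2 to compound 3 (0.10 log units; within the scatter) expected to stay within the scatter. Compound 3 is estimated at 2500 nM, in the range 1000 nM to 6000 nM.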

Compound 3, concentration for 50% growth inhibition: 11000 nM
Compound 3: the middle estimate sits 4.4-fold (0.64 log units) below what was measured, and the stated range ends below it.
By their numbers in this assay, from the lowest: compounds 2 and 1 (each within the scatter of the next); then compound 3.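

In this assay, this ring on a saturated chain carbon bound to an amine nitrogen can move the number beyond the scatter: trifluoromethyl in place of hydrogen on an aromatic carbon gives a 3.9-fold higher number from compound 1 to compound 3 (0.59 log units; beyond the scatter), and 4-chloro-3-(trifluoromethyl)phenyl in place of 4-(tert-butyl)phenyl gives a 5.5-fold higher number from compound 2 to compound 3 (0.74 log units; beyond the scatter). For the compounds shown here, the earlier exchange of chloro for tert-butyl stayed within the scatter, so the series now holds one ring change that leaves the number in place and others that raise it, with the added trifluoromethyl as the single difference in the step from compound 1. No measurement at hand accounts for this rise, which rests on compound 3 alone.

From the compounds shown here alone, whether the rise belongs to trifluoromethyl itself or would also follow from another group on that aromatic carbon, such as a nitrile, a methoxy or a fluoro, remains open. Also open, going by these compounds, is whether trifluoromethyl would raise the number on the 4-(tert-butyl)phenyl ring as well, and how a longer chain or an amide in place of the amine would read against these three compounds.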